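The compounds below may be only part of what the source reports. "The series", "measured", "known", "first", "only" and "open" are said of these compounds alone.

Measured compounds:

Compound 1 `O=[N+]([O-])c1ccc(COc2ccc(Nc3ncnc4cc5c(cc34)OCCOCCOCCOCCO5)cc2)cc1`: in a functional assay on SH-SY5Y cells (Homo sapiens) for antiproliferative activity, read by MTT assay, with a stated time of 72 h (a lower number here means a stronger inhibitor, a higher number a weaker inhibitor), compound 1 gives > 100000 nM, a limit of the assay rather than a number.

Compound 2 `O=[N+]([O-])c1ccc(COc2cccc(Nc3ncnc4cc5c(cc34)OCCOCCO5)c2)cc1`: in this assay compound 2 gives 36600 nM.

Compound 3 `c1ccc(COc2cccc(Nc3ncnc4cc5c(cc34)OCCOCCO5)c2)cc1`: compound 3 gives 68400 nM.

The difference between the core of compound 1 and the core of compound 2 is not broken down here. Between compound 2 and compound 3 the change is hydrogen in place of nitro on an aromatic carbon, and it gave a 1.9-fold higher number from compound 2 to compound 3 (0.27 log units; within the scatter). The same change is made from compound 1 to the unmeasured compound 4 `c1ccc(COc2ccc(Nc3ncnc4cc5c(cc34)OCCOCCOCCOCCO5)cc2)cc1`: hydrogen in place of nitro on an aromatic carbon. Within the data shown here, for compound 1 the only evidence is the limit of > 100000 nM in this assay, at which 1 of the 3 values shown sits. Resting on a 1.9-fold higher number from compound 2 to compound 3 (0.27 log units; within the scatter), the step expected in this assay is a step that the limit leaves unreadable from compound 1 to compound 4. Compound 4 is therefore estimated at about 150000 nM, and the assay may well again report only a limit.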

Compound 4, half-maximal inhibitory concentration: 5250 nM
The estimate for compound 4 lay 29-fold (1.46 log units) above the measured number; measured number below the stated range.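

In this assay, hydrogen in place of nitro gave an at least 19-fold lower number from compound 1 to compound 4 (1.27 log units; beyond the scatter), and this change does not carry over with the same size from one core to the other: the same change on two cores in this assay, a 1.9-fold higher number (0.27 log units; within the scatter) from compound 2 to compound 3 and an at least 19-fold lower number (1.27 log units; beyond the scatter) from compound 1 to compound 4, at least 35-fold (1.55 log units) apart, beyond the scatter of two such steps. Compound 1 stands at a limit of the assay and not at a number, so the step from it is only a bound: the limit of > 100000 nM in this assay, at which 1 of the 4 values shown sits. The two cores differ in more than one place, so the compounds shown do not tell which of those differences goes with the gap between the steps.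

Going by these compounds, it remains open how an amine or a carboxylic acid in place of nitro would read on either core. On these data alone, whether the step would hold on any third core is also open.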